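Furan-2-yl to Thiophen-2-yl: Expecting Little Change

A few compounds are considered here, and "the series" means these few. Any claim that something is new, unique, unknown or untested is made for them only; others in the source may bear on it.

Compound 3 `COc1ccc(-c2cc3ccccc3nc2/C=C/C(=O)c2ccco2)cc1` was tested in a functional assay on H184B5F5/M10 cells (Homo sapiens) for antiproliferative activity, read by XTT assay, with a stated time of 72 h (on this read-out higher numbers stand for weaker inhibition and lower numbers for stronger inhibition), where compound 3 gives 6240 nM. Among the three measured compounds this is the second highest number; compound 2 `COc1ccc(-c2cc3ccccc3nc2/C=C/C(=O)c2ccc([N+](=O)[O-])cc2)cc1` gives 6100 nM, and compound 1 `COc1ccc(-c2cc3ccccc3nc2/C=C/C(=O)c2ccccc2)cc1` gives 8560 nM, both within the scatter of compound 3. Compound 4 `COc1ccc(-c2cc3ccccc3nc2/C=C/C(=O)c2cccs2)cc1` differs from compound 3 by thiophen-2-yl in place of furan-2-yl on a carbonyl carbon. The measured steps that also exchange the group on the carbonyl carbon are a 1.4-fold lower number from compound 1 to compound 3 (0.14 log units; within the scatter) and a 1.0-fold higher number from compound 2 to compound 3 (0.01 log units; within the scatter); the remaining step, a 1.4-fold lower number from compound 1 to compound 2 (0.15 log units; within the scatter), likewise stayed within the scatter. Nothing measured here has moved the number beyond the scatter, so no step beyond the scatter is expected for compound 4 in this assay, that is a 1.0-fold lower number from compound 3 to compound 4 (0.02 log units; within the scatter). Compound 4 is therefore expected to give about 6000 nM, likely between 3000 nM and 12000 nM.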

Compound 4, half-maximal inhibitory concentration: 7030 nM
Compound 4: middle estimate off by 1.2-fold (0.07 log units), on the low side; measured number inside the range.
By their numbers in this assay, from the lowest: compounds 2, 3, 4 and 1 (each within the scatter of the next).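

In this assay the exchange of furan-2-yl for thiophen-2-yl on the carbonyl carbon gives a 1.1-fold higher number from compound 3 to compound 4 (0.05 log units; within the scatter) and so leaves the number within the scatter, even with sulfur in the ring in place of oxygen. The steps of a 1.2-fold higher number from compound 2 to compound 4 (0.06 log units; within the scatter) and a 1.2-fold lower number from compound 1 to compound 4 (0.09 log units; within the scatter) also stay within the scatter, so all four groups at this position read alike. Nothing at hand gives a reason for this.

On these data alone, whether an amine or a carboxylic acid on the carbonyl carbon would move the number beyond the scatter stays open. So does the effect of changes elsewhere on the shared core.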